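From dibutylamino to octylamino: a cytotoxicity step still unmeasured

A few compounds are considered here, and "the series" means these few. Any claim that something is new, unique, unknown or untested is made for them only; others in the source may bear on it.

Of the compounds shown here, three have so far been tested in an ADME assay on Vero cells (Chlorocebus sabaeus) for cytotoxicity, with a stated time of 72 h; on this read-out lower numbers stand for higher toxicity in this test and higher numbers for lower toxicity in this test. Compound 1 `O=C(/C=C/c1ccc(Cl)cc1)c1ccc(N2CCCCC2)cc1` gives 235 ug/mL, compound 2 `O=C(c1ccc(N2CCN(c3cccc(Cl)c3Cl)CC2)cc1)C1CC1c1ccc(Cl)cc1` gives 383 ug/mL, and compound 3 `CCCCN(CCCC)c1ccc(C(=O)C2CC2c2ccc(Cl)cc2)cc1` gives 431 ug/mL. Compound 3 thus stands within the usual scatter of repeated measurements of both others, so these numbers cannot be ranked.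

The next compound to be tested is compound 4 `CCCCCCCCNc1ccc(C(=O)C2CC2c2ccc(Cl)cc2)cc1`, which carries octylamino in place of dibutylamino on an aromatic carbon, para to a large group: octylamino in place of dibutylamino on an aromatic carbon. The two have the same atoms, joined differently.

Going by the values given here, no two measured compounds differ in just one place, so no measured step speaks directly to this change. Still, compound 2 at 383 ug/mL and compound 3 at 431 ug/mL carry different groups at this place, and their values lie within the scatter of each other. The expected change is therefore small, an estimated 1.4-fold lower number from compound 3 to compound 4 (0.16 log units; within the scatter), with nothing beyond the scatter expected. Compound 4 is expected near 300 ug/mL, with an estimated range from 130 ug/mL to 560 ug/mL.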

Compound 4, half-maximal cytotoxic concentration: 214 ug/mL
Compound 4: the middle estimate sits 1.4-fold (0.15 log units) above what was measured; low and high end bracket the measured number.
By their numbers in this assay, from the lowest: compounds 4, 1, 2 and 3 (each within the scatter of the next).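

Octylamino in place of dibutylamino gives a 2.0-fold lower number from compound 3 to compound 4 (0.30 log units; within the scatter) in this assay and is the first direct reading of a single change in this series. On an aromatic carbon, para to a large group, rearranging the same heavy atoms and adding a hydrogen-bond donor therefore leaves no difference that can be told from repeat-test scatter. Nothing measured here bears on this result.

The compounds shown leave open how this place responds to a group of another size or kind, such as a plain amino group, a butylamino chain or a carboxylic acid. They also leave open whether the same swap would again stay within the scatter on the core of compound 1 or the core of compound 2.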